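Methyl in place of hydrogen on an aromatic carbon

The compounds below may be only part of what the source reports. "The series", "measured", "known", "first", "only" and "open" are said of these compounds alone.

Measured compounds:
- compound 1 `COc1ccc(CN(c2cc(OC)c(OC)c(OC)c2)S(=O)(=O)c2ccc(C)cc2)cc1`: in a functional assay on PC-3 cells (Homo sapiens) for inhibition, read by MTT assay, with a stated time of 48 h (on this read-out higher numbers stand for weaker inhibition and lower numbers for stronger inhibition), compound 1 gives 8220 nM.
- compound 2 `COc1ccc(CN(c2cc(OC)c(OC)c(OC)c2)S(=O)(=O)c2ccccc2)cc1`: in this assay compound 2 gives only a limit of the assay, > 50000 nM.
- compound 3 `Cc1ccc(S(=O)(=O)N(Cc2nc3ccccc3[nH]2)c2ccccc2)cc1`: in this assay compound 3 gives only a limit of the assay, > 50000 nM.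

For the measured compounds named here, the one counted change among the measured compounds is methyl in place of hydrogen on an aromatic carbon. It brought an at least 6.0-fold lower number from compound 2 to compound 1 (0.78 log units; beyond the scatter); as compound 2 sits at a limit, only the lower bound of that step is known. Of the three values shown, two sit at the same limit, (the limit of > 50000 nM in this assay, at which 2 of the 3 values shown sit), so the series is read mostly at its upper edge.

The difference between the cores of compound 2 and compound 3 is not broken down here.

Compound 4 `Cc1ccc(N(Cc2nc3ccccc3[nH]2)S(=O)(=O)c2ccc(C)cc2)cc1` has not yet been measured. It differs from compound 3 by methyl in place of hydrogen on an aromatic carbon, the same change as that from compound 2 to compound 1, at a place described in the same words.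

In this assay the step is expected to be an at least 2.0-fold lower number from compound 3 to compound 4 (0.30 log units; that floor lies within the scatter), resting on the measured step of an at least 6.0-fold lower number from compound 2 to compound 1 (0.78 log units; beyond the scatter). Since compound 3 gives only a limit, a value for compound 4 may likewise stay at the limit rather than be a number. Compound 4 is estimated at 25000 nM, with a likely range from 6000 nM to 80000 nM.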

Compound 4, half-maximal inhibitory concentration: 48900 nM
For compound 4 the middle estimate is 2.0-fold (0.29 log units) below the measured one, within the range that was stated.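

Set side by side, the two steps of phenyl to 4-methylphenyl in this assay do not settle whether the change carries from one core to the other: the same change on two cores in this assay, an at least 6.0-fold lower number (0.78 log units; beyond the scatter) from compound 2 to compound 1 and an at least 1.0-fold lower number (0.00 log units; that floor lies within the scatter) from compound 3 to compound 4; the limit leaves it open whether they differ

The new step reads an at least 1.0-fold lower number from compound 3 to compound 4 (0.00 log units; that floor lies within the scatter), so compound 4 gives a number, but the step has only a floor, and the data neither confirm nor exclude a gain on this core of the size seen on the core of compound 2. Compound 3 gives only a limit of the assay, > 50000 nM, and compound 2 also stands at a limit, so the true size of both steps remains unknown: the limit of > 50000 nM in this assay, at which 2 of the 4 values shown sit.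

The compounds shown leave open how this methyl step behaves on a core whose unsubstituted member gives a number rather than a limit, which is what a direct comparison of the step across cores would need. Also open, as far as these compounds go, is whether another group on the same aromatic carbon, such as a chlorine atom, an amine or a carboxylic acid, would move the value in this assay on either core.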